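This account rests on a few compounds, and the source may have more. Where it says the series, first, only, none or still open, it means among the compounds named here.

Compound 1 `CN(C[C@H]1Cc2c(cccc2N2CCN(C3COC3)CC2)CN1)[C@H]1CCCc2cccnc21` bears a 4-(oxetan-3-yl)piperazin-1-yl group on its core. In a functional assay on CCRF-CEM cells for agonist activity at C-X-C chemokine receptor type 4 (Homo sapiens), read by calcium flux, with a stated time of 25 min (a lower number here means that less compound is needed, a higher number that more compound is needed for the effect), compound 1 gives > 30000 nM, which is a limit of the assay and not a measured number. Compound 2 `CN(C[C@@H]1Cc2c(cccc2N2CCNCC2)CN1)[C@H]1CCCc2cccnc21` carries a piperazin-1-yl group in place of that substituent. In this assay compound 2 likewise reaches only a limit, > 30000 nM. Both values thus sit at the limit of > 30000 nM in this assay, at which 2 of the 2 values shown sit, so compound 1 stands at the limit with no numerical potency to compare against.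

Compound 3 `CN(C[C@H]1Cc2c(cccc2N2CCNC(C)(C)C2)CN1)[C@H]1CCCc2cccnc21` is the next compound, and it differs from compound 1 by 3,3-dimethylpiperazin-1-yl in place of 4-(oxetan-3-yl)piperazin-1-yl on an aromatic carbon. Within the data shown here, no step between measured compounds is available here, since both known values are limits. Compound 3 is therefore expected to behave as compound 1 does, and the step of a number no higher from compound 1 to compound 3 (the limit leaves the size open) is estimated to be none beyond the scatter, with the most likely outcome being another limit. On that basis compound 3 is expected to show 30000 nM in this assay, within a range from 10000 nM to 100000 nM.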

Compound 3, half-maximal effective concentration: > 30000 nM
Compound 3 ended at the assay's limit (the forecaster's own chance of this, stated with the estimate: 85%); the middle value sits exactly at the limit.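

Compound 3 stands at the same limit of this assay as compound 1, so no step between the two can be read: the limit of > 30000 nM in this assay, at which 3 of the 3 values shown sit.

The compounds shown leave open whether any group at this place on the shared core gives a measurable value in this assay, and how 3,3-dimethylpiperazin-1-yl and 4-(oxetan-3-yl)piperazin-1-yl truly compare.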